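Hydroxamic acid chain length in a prostate cancer cell assay

The source may hold more compounds than are shown below. What is called first, only, known or untested is meant among the compounds shown, and "the series" means these compounds.

Compound 1 `C#CCN(C)Cc1cccc(NC(=O)CCC(=O)NO)c1` in a functional assay on DU-145 cells (Homo sapiens) for inhibition, read by MTT assay, with a stated time of 48 h (on this read-out higher numbers stand for weaker inhibition of growth and lower numbers for stronger inhibition of growth), gives > 10000 nM, a limit of the assay.
Compound 2 `C#CCN(C)Cc1cccc(NC(=O)CCCC(=O)NO)c1` in this assay gives > 10000 nM, a limit of the assay.
Compound 3 `C#CCN(C)Cc1ccc(NC(=O)CCCC(=O)NO)cc1` in this assay gives > 10000 nM, a limit of the assay.

All three values sit at the limit of > 10000 nM in this assay, at which 3 of the 3 values shown sit. The change from compound 1 to compound 2, ((hydroxycarbamoyl)methyl in place of hydroxycarbamoyl on a saturated chain carbon, two bonds along the chain from a carbonyl carbon), therefore gives a step that the two limits leave unreadable from compound 1 to compound 2. The cores of compound 1 and compound 3 differ, but that difference is not broken down here. Compound 4 `C#CCN(C)Cc1ccc(NC(=O)CCCCC(=O)NO)cc1` carries the same kind of change, ((hydroxycarbamoyl)methyl in place of hydroxycarbamoyl on a saturated chain carbon, three bonds along the chain from a carbonyl carbon); the place differs, being three bonds along the chain from a carbonyl carbon rather than two. Within the data shown here, the expected step is a step that the limit leaves unreadable from compound 3 to compound 4, because a step that the two limits leave unreadable from compound 1 to compound 2 is the only measured step of this kind and it is unreadable. Compound 4 is accordingly estimated at 15000 nM, between 3000 nM and 60000 nM, with a fair chance that only a limit is reported again.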

Compound 4, concentration for 50% growth inhibition: > 10000 nM
Compound 4: a limit, no number (the forecaster's own chance of this, stated with the estimate: 65%); the middle value is on the limit's open side.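

Compound 3 and compound 4 both give only a limit of the assay, not a number, so no step can be read between them: the limit of > 10000 nM in this assay, at which 4 of the 4 values shown sit.

From the compounds shown here alone, whether any chain length on these compounds gives a readable value in this assay stays open.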